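The source may hold more compounds than are shown below. What is called first, only, known or untested is meant among the compounds shown, and "the series" means these compounds.

Compound 3 `CN1CCC(c2ccc(Cl)cc2)C(C[S+]([O-])CC(=O)N(C)C)C1` carries a dimethylcarbamoyl group on a saturated chain carbon bound to a sulfur, and in an assay on isolated protein for inhibition of sodium-dependent dopamine transporter (Rattus norvegicus), read by radioligand binding (a higher number here means a weaker inhibitor, a lower number a stronger inhibitor), compound 3 gives 2880 nM, the highest number of the three measured compounds, which makes it the weakest inhibitor of the set. Compound 1 `COC(=O)C[S+]([O-])CC1CN(C)CCC1c1ccc(Cl)cc1` gives 231 nM in this assay, and compound 2 `COCC[S+]([O-])CC1CN(C)CCC1c1ccc(Cl)cc1` gives 15 nM. Compound 4 `Cc1noc(C[S+]([O-])CC2CN(C)CCC2c2ccc(Cl)cc2)n1` has not yet been measured; it differs from compound 3 in one place: 3-methyl-1,2,4-oxadiazol-5-yl in place of dimethylcarbamoyl on a saturated chain carbon bound to a sulfur. For the measured compounds named here, three measured steps concern exchanges at that same chain carbon: a 12-fold higher number from compound 1 to compound 3 (1.10 log units; beyond the scatter), a 15-fold lower number from compound 1 to compound 2 (1.19 log units; beyond the scatter) and a 190-fold higher number from compound 2 to compound 3 (2.28 log units; beyond the scatter). All three are large, and every exchange that removed the dimethylcarbamoyl group, or the methoxycarbonyl group, lowered the number. From the compounds shown here alone, a five-membered aromatic ring at this position is untested among the measured compounds, so the direction rests only on those steps; a lower number for compound 4 is expected, by a step of about a 14-fold lower number from compound 3 to compound 4 (1.16 log units; beyond the scatter). Compound 4 is accordingly estimated at 200 nM, with a range from 30 nM to 1500 nM.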

Compound 4, inhibition constant: 1650 nM
Compound 4: the middle estimate sits 8.3-fold (0.92 log units) below what was measured; the whole stated range lies below it.
By their numbers in this assay, from the lowest: compound 2; then compound 1; then compounds 4 and 3 (each within the scatter of the next).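

In this assay, the step from the dimethylcarbamoyl group to the 3-methyl-1,2,4-oxadiazol-5-yl ring is a 1.7-fold lower number from compound 3 to compound 4 (0.24 log units; within the scatter), so at this chain carbon the five-membered aromatic ring and the open-chain amide cannot be told apart. The ring does not bring the number close to that of the methoxymethyl group, with a 110-fold higher number from compound 2 to compound 4 (2.04 log units; beyond the scatter), and it also falls short of the methoxycarbonyl group, with a 7.1-fold higher number from compound 1 to compound 4 (0.85 log units; beyond the scatter). No supporting data are available to explain these steps.

From the compounds shown here alone, it remains open whether the much lower number of compound 2 is specific to methoxymethyl or would persist with a longer ether chain such as ethoxymethyl. How a carboxylic acid or an amine on this same chain carbon would compare is also unknown.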